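Replacing the Ring Cap with a Smaller Fluorinated Ring

The source may hold more compounds than are shown below. What is called first, only, known or untested is meant among the compounds shown, and "the series" means these compounds.

In a functional assay on CHO cells with adenosine receptor A1 (Homo sapiens) as the target, read by cAMP accumulation and immunoassay, with a stated time of 6 min, tested at 0.1 uM (on this read-out higher numbers stand for a weaker effect at the one concentration tested and lower numbers for a stronger effect), compound 1 `Nc1scc(CN2CCN(c3ccccc3C(F)(F)F)CC2)c1C(=O)c1ccc(Cl)cc1` gives -7.5%, the highest of the three numbers shown, although compound 3 `Nc1scc(CN2CCN(c3ccc(C(F)(F)F)cc3)CC2)c1C(=O)c1cccc(C(F)(F)F)c1` at -11% and compound 2 `Nc1scc(CN2CCN(c3ccc(OC(F)(F)F)cc3)CC2)c1C(=O)c1ccc(Cl)cc1` at -13% both lie within the scatter of it. Going by the values given here, the only measured step that changes a single place, a number 5.5 percentage points lower from compound 1 to compound 2 (within the scatter), stayed within the scatter. Compound 4 `Nc1scc(CN2CCN(c3c(F)cccc3F)CC2)c1C(=O)c1ccc(Cl)cc1` differs from compound 1 by 2,6-difluorophenyl in place of 2-(trifluoromethyl)phenyl on an amine nitrogen in a ring. Among the compounds with values here, that one step to compound 2 is the only measured change of the group on the ring nitrogen, and it moved nothing beyond the scatter, so no movement beyond the scatter is expected here either. For compound 4 an essentially unchanged reading is expected, a step of a number 0.5 percentage points lower from compound 1 to compound 4 (within the scatter). Compound 4 is estimated at -8%, with a range from -20% to 5%.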

Compound 4, a percentage reported as activity, at one concentration (the size of the read-out at that concentration, not a potency): -23%
Compound 4: middle estimate off by 15 percentage points, on the high side, and the stated range ends above it.
By their numbers in this assay, from the lowest: compounds 4, 2, 3 and 1 (each within the scatter of the next, the first and the last beyond it).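

In this assay, going by these compounds alone, the group on the ring nitrogen can shift the reading: 2,6-difluorophenyl gives a number 15.5 percentage points lower from compound 1 to compound 4 (beyond the scatter) for the swap from 2-(trifluoromethyl)phenyl, the first modest step here to pass the scatter. Set against the 4-(trifluoromethoxy)phenyl group, the same change gives a number 10 percentage points lower from compound 2 to compound 4 (within the scatter) and so does not separate the two groups. Nothing available explains why the first step is larger.

The compounds shown leave open whether the shift follows the two fluorine atoms or the loss of trifluoromethyl. A plain phenyl or a methoxyphenyl group at this place could help to separate those two readings.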